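This account rests on a few compounds, and the source may have more. Where it says the series, first, only, none or still open, it means among the compounds named here.

Compounds measured in an assay for binding affinity to Alpha-1A adrenergic receptor (Homo sapiens); on this read-out lower numbers stand for stronger inhibition and higher numbers for weaker inhibition:
Compound 1, `CN1CCC[C@@H]1Cn1nc(CC2CCCCC2)c2ccccc2c1=O`: a limit, > 1990 nM.
Compound 2, `CN1CCC[C@@H]1Cn1nc(Cc2ccc(F)cc2)c2ccccc2c1=O`: 63.1 nM.
Compound 3, `COC(=O)c1ccc(Cc2nn(C[C@H]3CCCN3C)c(=O)c3ccccc23)cc1`: a limit, > 1990 nM.

Within the data shown here, compound 2 is the only compound with a number; the other two sit at the limit of > 1990 nM in this assay, at which 2 of the 3 values shown sit. Compound 4, `COc1cccc(Cc2nn(C[C@H]3CCCN3C)c(=O)c3ccccc23)c1`, is unmeasured and differs from compound 2 by 3-methoxyphenyl in place of 4-fluorophenyl on a saturated chain carbon bound to an aromatic carbon. Among the measured compounds shown here, two steps bear on this change. The step of an at least 31-fold lower number from compound 1 to compound 2 (1.49 log units; beyond the scatter) shows a large gain on moving to the 4-fluorophenyl group. The step of an at least 31-fold higher number from compound 2 to compound 3 (1.49 log units; beyond the scatter) shows a large loss when the fluoro on that ring is replaced. Compound 4 changes both the substituent and its ring position, so a moderate weakening is expected, a 5.1-fold higher number from compound 2 to compound 4 (0.71 log units; beyond the scatter). Compound 4 is estimated at 320 nM, between 60 nM and 2000 nM.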

Compound 4, inhibition constant: 1580 nM
For compound 4 the middle estimate is 4.9-fold (0.69 log units) below the measured one; low and high end bracket the measured number.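

The 3-methoxyphenyl group keeps the aromatic ring, yet it gives a 25-fold higher number from compound 2 to compound 4 (1.40 log units; beyond the scatter). Set against the cyclohexyl group, the same ring gives an at least 1.2-fold lower number from compound 1 to compound 4 (0.10 log units; that floor lies within the scatter), so the gain seen with 4-fluorophenyl does not carry over to 3-methoxyphenyl. Compound 1 and compound 3 remain limits, not numbers: the limit of > 1990 nM in this assay, at which 2 of the 4 values shown sit.

As far as these compounds go, whether the loss follows the substituent or its ring position stays open, since compound 4 changes both; a 4-methoxyphenyl or 3-fluorophenyl group would separate the two. From the compounds shown here alone, how an amine or a carboxylic acid on this ring would read also remains unknown.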